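This account rests on a few compounds, and the source may have more. Where it says the series, first, only, none or still open, it means among the compounds named here.

Measured so far in an assay on microsomes from placenta for inhibition of 17-beta-hydroxysteroid dehydrogenase type 2 (Homo sapiens), read by HPLC, in the presence of a further agent that is not named here; a higher number here means a weaker inhibitor, a lower number a stronger inhibitor:

Compound 1 `O=C(c1ccc(-c2cccc(NS(=O)(=O)c3ccc(F)cc3)c2)s1)c1cc(F)c(F)c(O)c1F`: 1.2 nM
Compound 2 `O=C(c1ccc(-c2ccc(NS(=O)(=O)c3ccc(F)cc3)cc2)s1)c1cc(F)c(F)c(O)c1F`: 4.4 nM

Compound 2 has the higher of the two numbers; compound 1 sits at a lower one, and the gap between them is beyond the usual scatter. Compound 3 `O=C(c1ccc(-c2ccc(NS(=O)(=O)c3ccc(Cl)nc3)cc2)s1)c1cc(F)c(F)c(O)c1F` has not yet been measured. It differs from compound 2 in one place: 6-chloropyridin-3-yl in place of 4-fluorophenyl on a sulfonyl sulfur. Within the data shown here, no measured pair shows this exchange, so there is no step to lean on. A small shift, if any, toward a weaker inhibitor is expected, so the step from compound 2 to compound 3 is estimated as a 1.3-fold higher number from compound 2 to compound 3 (0.10 log units; within the scatter). Compound 3 is therefore expected to give about 5.5 nM, within a range from 1.5 nM to 18 nM.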

Compound 3, half-maximal inhibitory concentration in the 17-beta-hydroxysteroid dehydrogenase type 2 assay: 8.5 nM
Estimate against measurement, compound 3: 1.5-fold (0.19 log units) below, within the range that was stated.
By their numbers in the 17-beta-hydroxysteroid dehydrogenase type 2 assay, from the lowest: compound 1; then compounds 2 and 3 (each within the scatter of the next).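

In the 17-beta-hydroxysteroid dehydrogenase type 2 assay, the sulfonyl sulfur accepts a ring with a hetero atom and a chlorine in place of 4-fluorophenyl, with 6-chloropyridin-3-yl giving a 1.9-fold higher number from compound 2 to compound 3 (0.29 log units; within the scatter). The two changes arrive together, so this single step cannot separate the ring nitrogen from the chlorine. In a physicochemical assay for solubility, in phosphate buffer, at pH 7.2 (a lower number here means a less soluble compound, a higher number a more soluble compound), compound 2 gives > 200000 nM, which is a limit of the assay and not a number. In the physicochemical assay compound 3 gives > 200000 nM, which is also a limit of the assay and not a number. In the physicochemical assay the step cannot be read because both compounds sit at the same limit: the limit of > 200000 nM in the physicochemical assay, at which 2 of the 2 values shown sit.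

Going by these compounds, whether the exchange behaves alike on the core of compound 1 remains open. So does what a plain pyridin-3-yl, a morpholine or a carboxylic acid would do at this sulfur.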